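The compounds below may be only part of what the source reports. "The series", "measured", "known", "first", "only" and "open" are said of these compounds alone.

Compound 1 `Cn1cc(C(=O)Nc2ccc(-c3ccccc3)c(C(F)(F)F)c2)c(=O)c2ccncc21` gives 6.1 ug/mL in a physicochemical assay for solubility, in simulated intestinal fluid, at pH 7.4 (a lower number here means a less soluble compound, a higher number a more soluble compound), and compound 2 `COc1ccncc1C(=O)NC(=O)Nc1ccc(-c2ccccc2)c(C(F)(F)F)c1` gives 16 ug/mL in the same measurement. Compound 3 `Cn1cc(C(=O)Nc2ccc(-c3ccccc3)c(C(F)(F)F)c2)c(=O)c2ccccc21` stands at 11 ug/mL in this assay and lies within the scatter of both others, so these numbers do not separate the three compounds. Compound 4 `Cn1cc(C(=O)Nc2ccc(-c3ccncc3)c(C(F)(F)F)c2)c(=O)c2ccccc21` departs from compound 3 in a single place: pyridin-4-yl in place of phenyl on an aromatic carbon, ortho to a trifluoromethyl group (pyridin-4-yl in place of phenyl on an aromatic carbon). Going by the values given here, no pair of measured compounds shows this exchange on its own, so the series offers no direct precedent for it. A small rise in this assay is expected all the same, although it may well stay within the scatter. The estimate is a step of a 1.6-fold higher number from compound 3 to compound 4 (0.21 log units; within the scatter) in the upward direction, and it rests on judgement rather than on a measured pair. Compound 4 is expected at 18 ug/mL (estimated range 6 ug/mL to 50 ug/mL).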

Compound 4, solubility: 12 ug/mL
Compound 4: the middle estimate sits 1.5-fold (0.18 log units) above what was measured; the range from low to high includes it.
By their numbers in this assay, from the lowest: compounds 1, 3, 4 and 2 (each within the scatter of the next, the first and the last beyond it).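

In this assay, going by these compounds alone, the exchange of phenyl for pyridin-4-yl on an aromatic carbon, ortho to a trifluoromethyl group, gives a 1.1-fold higher number from compound 3 to compound 4 (0.04 log units; within the scatter) and is the first single exchange that the series allows to be read directly. At this position, then, bringing in a ring nitrogen with one hydrogen-bond acceptor does not separate compound 4 from compound 3 in this measurement. No available measurement offers an explanation for this result.

As far as these compounds go, whether a pyridin-3-yl ring, a morpholine or a carboxylic acid at this same place would move the number beyond the scatter remains open. From the compounds shown here alone, it is also open whether pyridin-4-yl in place of phenyl would give a similar result on the core of compound 1 or on that of compound 2.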